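The source may report more compounds than this note shows. Statements on the series, on what has been measured and on what is new or still open speak of the compounds shown alone.

Compound 1 `O=c1ccn(CCCCCOc2ccc(-c3ccccc3)cc2)c(=O)[nH]1` was tested in an ADME assay on HEL cells (Homo sapiens) for cytotoxicity, read by microscopy (a lower number here means that less compound is tolerated, a higher number that more compound is tolerated), where compound 1 gives 100000 nM. Compound 2 `Cc1cn(CCCCCOc2ccc(Br)cc2)c(=O)[nH]c1=O` gives 100000 nM in this assay, level with compound 1 within the usual scatter. Compound 3 `O=c1ccn(CCCOc2ccc(Br)cc2)c(=O)[nH]1` reaches only a limit of the assay, > 100000 nM, so no number is known for it; the limit of > 100000 nM in this assay, at which 1 of the 3 values shown sits, marks that limit. Compound 4 `O=c1ccn(CCCCCOc2ccccc2)c(=O)[nH]1` has not yet been measured. Compared with compound 1 the change is hydrogen in place of phenyl on an aromatic carbon. Among the compounds with values here, nothing among the measured compounds shows a step in this assay for this kind of change, and the two numbers known sit together, so the expectation for compound 4 is no step beyond the scatter, no change at the digits printed from compound 1 to compound 4 (within the scatter). Compound 4 is therefore estimated at 100000 nM, within a range of 50000 nM to 200000 nM.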

Compound 4, minimum cytotoxic concentration: > 100000 nM
Compound 4: only a limit was reported; the forecaster's own chance of this, stated with the estimate: 40%; the middle value lies on the limit itself.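

In this assay, hydrogen in place of phenyl gives a number no lower from compound 1 to compound 4 (the limit leaves the size open). This is the first step shown at this position, and it shows that removing the phenyl ring does not make the compound less tolerated by these cells. The value for compound 4 is a limit, not a number, and it is not alone there: the limit of > 100000 nM in this assay, at which 2 of the 4 values shown sit.

The compounds shown leave open how large the step really is. They also leave open whether an amine or a carboxylic acid on this aromatic carbon would give a readable number.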